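This account rests on a few compounds, and the source may have more. Where it says the series, first, only, none or still open, it means among the compounds named here.

Measured so far in a functional assay on A-375 cells (Homo sapiens) for antiproliferative activity, read by MTT assay, with a stated time of 24 h (a lower number here means a stronger inhibitor, a higher number a weaker inhibitor), are two compounds:

- Compound 1 `COc1cc(OC)c(-c2coc3cc(OCc4cccc(F)c4)ccc3c2=O)cc1OC` gives 1300 nM 
- Compound 2 `COc1cc(OC)c(-c2coc3cc(OCc4ccccc4Br)ccc3c2=O)cc1OC` gives 2850 nM 

Of these two numbers, compound 2 has the higher one (2850 nM), which makes it the weaker inhibitor of the pair. Compound 3 `COc1cc(OC)c(-c2coc3cc(OCc4ccc(C(F)(F)F)cc4)ccc3c2=O)cc1OC` has not yet been measured. It keeps the shared core and puts 4-(trifluoromethyl)phenyl in place of 2-bromophenyl on a saturated chain carbon bound to an oxygen on an aromatic ring with nothing else changed. Going by the values given here, only one measured step bears on this, a 2.2-fold higher number from compound 1 to compound 2 (0.34 log units; beyond the scatter) and it is modest. It also exchanges one substituted phenyl for another at that same place. Among the compounds with values here, no measured compound carries the incoming group, so the evidence is thin. Compound 1, without the 2-bromophenyl, gives 1300 nM so a modest move toward a lower number is expected, possibly no larger than the scatter. The estimated change is a 1.6-fold lower number from compound 2 to compound 3 (0.20 log units; within the scatter) in this assay and no large jump is expected. For compound 3 the estimated value is 1800 nM (expected range 700 nM to 4500 nM).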

Compound 3, half-maximal inhibitory concentration: 2280 nM
The estimate for compound 3 lay 1.3-fold (0.10 log units) below the measured number; the range from low to high includes it.
By their numbers in this assay, from the lowest: compounds 1, 3 and 2 (each within the scatter of the next, the first and the last beyond it).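

In this assay, placing 4-(trifluoromethyl)phenyl on the saturated chain carbon bound to an oxygen on an aromatic ring gives a 1.3-fold lower number from compound 2 to compound 3 (0.10 log units; within the scatter) and a 1.8-fold higher number from compound 1 to compound 3 (0.24 log units; within the scatter), so compound 3 cannot be told apart from either of the other two compounds. The three substituted phenyl groups thus stay close together at this position, although compound 1 and compound 2 remain separated by more than the scatter. Nothing measured here explains the closeness of these results.

The compounds shown leave open whether the gap between compound 1 and compound 2 comes from the identity of the halogen or from where it sits on the ring. They also leave open how this position would respond to a group of a different kind, such as an amine, a carboxylic acid or a longer chain in place of the benzyl group.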